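Methyl to chloro on the aryl ring of compound 3

The source may report more compounds than this note shows. Statements on the series, on what has been measured and on what is new or still open speak of the compounds shown alone.

compound 1 `Cc1ccc(C(CCN(C)C)NC(=O)CCc2ccccc2)cc1`: 4570 nM
compound 2 `CN(C)CCC(NC(=O)C#Cc1ccccc1)c1ccc(Cl)cc1`: 398 nM
compound 3 `Cc1ccc(C(CCN(C)C)NC(=O)CCc2ccc(C(F)(F)F)cc2)cc1`: 2290 nM

All three have been run in a functional assay on NIH3T3 cells for agonist activity at Urotensin-2 receptor (Homo sapiens), with a stated time of 5 days; on this read-out higher numbers stand for an effect only at larger amounts of compound and lower numbers for an effect already at smaller amounts. Compound 3 stands second highest of the three numbers; compound 1 is nearest, the step of a 2.0-fold lower number from compound 1 to compound 3 (0.30 log units; within the scatter) lying within the scatter, and compound 2 is furthest, its number beyond the scatter away from that of compound 3. Compound 4 `CN(C)CCC(NC(=O)CCc1ccc(C(F)(F)F)cc1)c1ccc(Cl)cc1` has not been run in this assay. Its change from compound 3 is chloro in place of methyl on an aromatic carbon. For the measured compounds named here, no measured step covers this change: the one single-point step, from compound 1 to compound 3, concerns the trifluoromethyl end of the molecule and says nothing about the aryl ring next to the amine chain. Compound 2 does carry the 4-chlorophenyl, but it also differs from compound 3 in the amide part, so its lower number cannot be assigned to the chloro alone; it only hints that chloro is tolerated. The expected step in this assay is therefore a 1.9-fold lower number from compound 3 to compound 4 (0.28 log units; within the scatter), a modest move toward a lower number, held with wide uncertainty. The estimate for compound 4 is 1200 nM, expected within 300 nM to 4500 nM.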

Compound 4, half-maximal effective concentration: 1120 nM
Compound 4: the middle estimate sits 1.1-fold (0.03 log units) above what was measured, and the stated range covers the measured number.
By their numbers in this assay, from the lowest: compound 2; then compound 4; then compounds 3 and 1 (each within the scatter of the next).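

In this assay, for the compounds shown here, the swap of methyl for chloro on an aromatic carbon para to a large group gives a 2.0-fold lower number from compound 3 to compound 4 (0.31 log units; beyond the scatter), the first step at this position read between two compounds that differ in one place only. Going by these compounds alone, the only earlier such step, a 2.0-fold lower number from compound 1 to compound 3 (0.30 log units; within the scatter), concerned the trifluoromethyl at the other end of the molecule and lay within the scatter, whereas the change from 4-methylphenyl to 4-chlorophenyl is modest in size but beyond it, so this position has a measurable effect on the read-out and the chloro is more than merely tolerated. Nothing on hand explains the step, which stands as an observation only.

The compounds shown leave open whether other groups at this position, such as bromo, methoxy or a nitrile, would move the number further, or whether hydrogen there would fall on the chloro or the methyl side. They also leave open whether the same change holds with the alkyne amide of compound 2, whose 4-methylphenyl partner is not among the compounds shown here.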